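Adding Chlorine to a Vitamin D Receptor Antagonist Scaffold

The source may hold more compounds than are shown below. What is called first, only, known or untested is meant among the compounds shown, and "the series" means these compounds.

Of the compounds shown here, three with a shared core have been measured in an assay on HEK-293T cells for antagonist activity at vitamin D3 receptor (Homo sapiens), read by a luciferase reporter, with a stated time of 24 h; a higher number here means a weaker inhibitor, a lower number a stronger inhibitor. Compound 1 `CC(C)c1onc(-c2c(Cl)cccc2Cl)c1COc1ccc(-c2nc3ccc(C(=O)O)cc3n2C)cc1` gives 7150 nM and stands weakest of the three, since every step away from it lies beyond the usual scatter. Compound 2 `CC(C)c1onc(-c2c(Cl)cccc2Cl)c1COc1ccc(-c2nc3ccc(C(=O)O)cc3n2CC2CCCCC2)cc1` gives 346 nM; it differs from compound 1 by hydrogen in place of cyclohexyl on a saturated chain carbon bound to an aromatic nitrogen, and the step of a 21-fold lower number from compound 1 to compound 2 (1.32 log units; beyond the scatter) is large. Compound 3 `CC(C)c1onc(-c2c(Cl)cccc2Cl)c1COc1ccc(-c2nc3ccc(C(=O)O)cc3n2CC2CCCCC2)c(Cl)c1` gives 160 nM. It arises from compound 2 by chloro in place of hydrogen on an aromatic carbon, a modest gain of a 2.2-fold lower number from compound 2 to compound 3 (0.33 log units; beyond the scatter).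

Compound 4 `CC(C)c1onc(-c2c(Cl)cccc2Cl)c1COc1ccc(-c2nc3ccc(C(=O)O)cc3n2C)cc1Cl` has not yet been measured in this assay. It arises from compound 1 by chloro in place of hydrogen on an aromatic carbon, and the place where the chloro enters is described in the same words as for compound 3, so this is the same change seen once before, on the core that lacks the cyclohexyl. For the measured compounds named here, with only one earlier example, the expectation leans on it alone: a step of about a 2.2-fold lower number from compound 1 to compound 4 (0.34 log units; beyond the scatter) is expected, because the earlier step of a 2.2-fold lower number from compound 2 to compound 3 (0.33 log units; beyond the scatter) was modest. Compound 4 is therefore estimated at 3300 nM, within 1500 nM to 7500 nM.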

Compound 4, half-maximal inhibitory concentration: 2450 nM
For compound 4 the middle estimate is 1.3-fold (0.13 log units) above the measured one; measured number inside the range.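

In this assay, adding the chloro to the core without the cyclohexyl gives a 2.9-fold lower number from compound 1 to compound 4 (0.47 log units; beyond the scatter), so the gain seen earlier on the core with the cyclohexyl appears here too. For the compounds shown here, the two steps run the same way, and their sizes cannot be told apart: the same change on two cores in this assay, a 2.2-fold lower number (0.33 log units; beyond the scatter) from compound 2 to compound 3 and a 2.9-fold lower number (0.47 log units; beyond the scatter) from compound 1 to compound 4, 1.3-fold (0.13 log units) apart, within the scatter of two such steps This shows only that the change carried over between these two closely related cores, at one place on the ring and in one assay; it does not show that the chloro would act the same way on a more distant core, and it does not explain why the number falls.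

The compounds shown leave open whether fluoro, methoxy or a nitrile on the same aromatic carbon would lower the number as chloro does. They also leave open how a simple straight chain, such as butyl, would compare with the cyclohexyl on the saturated chain carbon bound to the aromatic nitrogen.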